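A few compounds are considered here, and "the series" means these few. Any claim that something is new, unique, unknown or untested is made for them only; others in the source may bear on it.

Measured compounds, with their values in a functional assay on ACHN cells (Homo sapiens) for cytotoxicity; a higher number here means a weaker inhibitor, a lower number a stronger inhibitor:
compound 1, `CO/N=c1\[nH]cnc2c1[n+](C/C=C(\C)CC/C=C(\C)CC/C=C(\C)CCC=C(C)C)cn2CCC#N`, gives 11400 nM
compound 2, `CC(C)=CCC/C(C)=C/CC/C(C)=C/CC/C(C)=C/C[n+]1cn(CCC#N)c2nc[nH]/c(=N\OCc3ccccc3)c21`, gives 38900 nM
compound 3, `CO/N=c1\[nH]cnc2c1[n+](C/C=C(\C)CC/C=C(\C)CC/C=C(\C)CCC=C(C)C)cn2Cc1ccccc1`, gives 3400 nM

Two changes on compound 1 are measured. phenyl in place of hydrogen on a saturated chain carbon bound to an oxygen produces a 3.4-fold higher number from compound 1 to compound 2 (0.53 log units; beyond the scatter). The second change produces a 3.4-fold lower number from compound 1 to compound 3 (0.53 log units; beyond the scatter), which leaves compound 3 with the lowest of the three numbers, its steps to the other two both beyond the scatter.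

Compound 4, `CO/N=c1\[nH]cnc2c1[n+](C/C=C(\C)CC/C=C(\C)CC/C=C(\C)CCC=C(C)C)cn2C(c1ccccc1)c1ccccc1`, is not yet measured in this assay. It differs from compound 3 by phenyl in place of hydrogen on a saturated chain carbon bound to an aromatic carbon and an aromatic nitrogen. This is the same kind of change as that from compound 1 to compound 2, phenyl in place of hydrogen, but not the same: there the saturated chain carbon is bound to an oxygen, here to an aromatic carbon and an aromatic nitrogen. The two cores also differ, by phenyl in place of cyanomethyl on a saturated chain carbon bound to an aromatic nitrogen, so the earlier step is only a rough guide.

A modest weakening is expected for compound 4, a 1.8-fold higher number from compound 3 to compound 4 (0.25 log units; within the scatter), because the same kind of change gave a 3.4-fold higher number from compound 1 to compound 2 (0.53 log units; beyond the scatter), with wide uncertainty given the different place. Compound 4 is thus estimated near 6000 nM, in a range from 1800 nM to 20000 nM.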

Compound 4, half-maximal inhibitory concentration: 4750 nM
For compound 4 the middle estimate is 1.3-fold (0.10 log units) above the measured one; the measured number falls inside the stated range.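

In this assay, phenyl in place of hydrogen on a saturated chain carbon bound to an aromatic carbon and an aromatic nitrogen gives a 1.4-fold higher number from compound 3 to compound 4 (0.15 log units; within the scatter). Set beside the earlier phenyl-for-hydrogen step, the two results cannot be told apart, so no dependence on the core can be claimed from them: the same change on two cores in this assay, a 3.4-fold higher number (0.53 log units; beyond the scatter) from compound 1 to compound 2 and a 1.4-fold higher number (0.15 log units; within the scatter) from compound 3 to compound 4, 2.4-fold (0.39 log units) apart, within the scatter of two such steps. Going by these compounds alone, this does not show that the change carries over with a fixed size, as only two pairs are available, the phenyl enters at a different carbon in each, and the core and the place of the change vary together.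

Still open, from the compounds shown here alone, is how phenyl in place of hydrogen on the saturated chain carbon bound to an oxygen reads on the core of compound 3, which would compare the two cores at one place. Also open, going by these compounds, is how an amine or a carboxylic acid on the added phenyl would read in this assay.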